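A few compounds are considered here, and "the series" means these few. Any claim that something is new, unique, unknown or untested is made for them only; others in the source may bear on it.

Compound 1 `N=C(N)c1cccc(N2CC(OCc3ccccc3)CN(CC3CCN(Cc4ccccc4)CC3)C2=O)c1` stands as the stronger of the two compounds measured in an assay on isolated protein for inhibition of Suppressor of tumorigenicity 14 protein (Homo sapiens), read by fluorescence; a lower number here means a stronger inhibitor, a higher number a weaker inhibitor. In this assay compound 1 gives 1540 nM. Compound 2 `CC1CN(Cc2cccc(C(=N)N)c2)C(=O)N(C2CCN(Cc3ccccc3)CC2)C1` differs from compound 1 in several places. In this assay compound 2 gives 13500 nM, a number that lies well beyond the scatter from that of compound 1. These two alone show only that the whole set of differences between them weakens inhibition; no single change can be read off.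

Compound 3 `COCC1CN(CC2CCN(Cc3ccccc3)CC2)C(=O)N(c2cccc(C(=N)N)c2)C1` has not yet been measured. It differs from compound 1 in one place: methoxymethyl in place of benzyloxy on a saturated ring carbon. Among the measured compounds shown here, no measured pair in this assay shows how such a change moves the inhibition constant, so the direction is open. Given that compound 1 stands at 1540 nM and that the benzyloxy group with its one six-membered aromatic ring leaves while the short methoxymethyl enters, the step of a 1.9-fold higher number from compound 1 to compound 3 (0.29 log units; within the scatter) is expected to be a modest weakening. Compound 3 is therefore estimated at 3000 nM in this assay, with a range from 1000 nM to 10000 nM.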

Compound 3, inhibition constant: 850 nM
The estimate for compound 3 lay 3.5-fold (0.55 log units) above the measured number; measured number outside the range, below it.
By their numbers in this assay, from the lowest: compounds 3 and 1 (each within the scatter of the next); then compound 2.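

In this assay, putting methoxymethyl in place of benzyloxy on a saturated ring carbon comes to a 1.8-fold lower number from compound 1 to compound 3 (0.26 log units; within the scatter) and so leaves compound 1 and compound 3 level. Among the compounds shown here, this is the first single-place comparison, whereas compound 1 and compound 2 differ in several places at once: at this position, the six-membered aromatic ring of benzyloxy and most of its heavy atoms can go without a change in the inhibition constant that stands clear of the scatter, while each group brings one oxygen and one hydrogen-bond acceptor. Nothing measured on these compounds accounts for this result, and the comparison gives no reason for it.

This one pair cannot show whether the oxygen that both groups carry matters at this position, and the methyl group of compound 2 gives no answer, as that compound also differs from compound 1 elsewhere. On these data alone, how an alcohol such as hydroxymethyl, an amine such as aminomethyl, a carboxylic acid or a longer ether chain on the same ring carbon would move the inhibition constant remains open.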